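The compounds below may be only part of what the source reports. "The series", "measured", "known", "first", "only" and "open" are said of these compounds alone.

The series shares one core and varies only the five-membered aromatic ring attached to it. Compound 1 `Oc1ccc(-c2cc(-c3cccs3)nc(-c3ccccc3Cl)c2)cc1` carries a thiophen-2-yl group and gives, in a functional assay on T47D cells (Homo sapiens) for cytotoxicity, read by CCK-8 assay and cell counting, with a stated time of 2 days (on this read-out lower numbers stand for stronger inhibition and higher numbers for weaker inhibition), a value of 5870 nM. Compound 2 `Oc1ccc(-c2cc(-c3ccco3)nc(-c3ccccc3Cl)c2)cc1` carries a furan-2-yl group in the same place and gives in this assay a value of 5480 nM. The step between them, a 1.1-fold lower number from compound 1 to compound 2 (0.03 log units; within the scatter), stays within the scatter, so the two compounds cannot be ranked against each other. Going by the values given here, compound 2 thus holds the lowest of the two numbers so far, but only by a margin that the scatter covers.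

Compound 3 `Oc1ccc(-c2cc(-c3ccsc3)nc(-c3ccccc3Cl)c2)cc1` has not been measured. It differs from compound 2 in one place: thiophen-3-yl in place of furan-2-yl on an aromatic carbon. Among the compounds with values here, only one measured step bears on this change, the exchange of thiophen-2-yl for furan-2-yl from compound 1 to compound 2, which left the number essentially unchanged. On that basis the expected step in this assay is none beyond the scatter, a 1.0-fold higher number from compound 2 to compound 3 (0.02 log units; within the scatter). Compound 3 is therefore estimated at 5700 nM, with a range from 2500 nM to 13000 nM.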

Compound 3, half-maximal inhibitory concentration: 6110 nM
Compound 3: the middle estimate sits 1.1-fold (0.03 log units) below what was measured; the range from low to high includes it.
By their numbers in this assay, from the lowest: compounds 2, 1 and 3 (each within the scatter of the next).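

The new compound widens the comparison in two ways. In this assay, exchanging furan-2-yl for thiophen-3-yl on the aromatic carbon next to the ring nitrogen gives a 1.1-fold higher number from compound 2 to compound 3 (0.05 log units; within the scatter), and changing only the point of attachment of the thiophene, from thiophen-2-yl to thiophen-3-yl, gives a 1.0-fold higher number from compound 1 to compound 3 (0.02 log units; within the scatter). The earlier pair had tested only a change from sulfur to oxygen in a ring attached through its 2-position, whereas these steps show that neither that exchange nor the change in attachment separates the compounds at this position, and no measurement available here explains why these three rings cannot be told apart.

Going by these compounds, all three compounds carry a five-membered aromatic ring with 1 hetero atom at this position, so it remains open whether an amine, a carboxylic acid or a longer alkyl chain in the same place would produce a step beyond the scatter. The 2-chlorophenyl and 4-hydroxyphenyl groups are the same throughout, which leaves open what replacing either of them, for example the chlorine by a methoxy group, would do to the number.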